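The source may hold more compounds than are shown below. What is called first, only, known or untested is meant among the compounds shown, and "the series" means these compounds.

In an in vitro functional assay on cells for antagonist activity at B1 bradykinin receptor (Homo sapiens), read by luminescence and calcium flux, with a stated time of 2 h (on this read-out lower numbers stand for stronger inhibition and higher numbers for weaker inhibition), three compounds have been measured. Compound 1 `CC(=O)N1CCC(NC(=O)C[C@@H]2C(=O)NC=CN2S(=O)(=O)c2ccc(C)cc2)c2ccccc21` gives 72.2 nM in this assay, and compound 2 `Cc1ccc(S(=O)(=O)N2C=CNC(=O)[C@H]2CC(=O)N[C@@H]2CC(=O)Nc3ccccc32)cc1` gives 96 nM. Compound 3 `Cc1ccc(S(=O)(=O)N2C=CNC(=O)[C@H]2CC(=O)NC2CCCCC2)cc1` gives 990 nM, the highest of the three numbers; its gaps to compound 2 and to compound 1 both lie beyond the usual scatter, so compound 3 is the weakest of the measured compounds in this assay. Compound 4 `Cc1ccc(S(=O)(=O)N2C=CNC(=O)[C@H]2CC(=O)N[C@H]2CCN(C)CC2(C)C)cc1` has not yet been measured. It differs from compound 3 in one place: a group of 9 heavy atoms (8 carbon, 1 nitrogen; one six-membered non-aromatic ring with 1 hetero atom) in place of a group of 6 heavy atoms (6 carbon; one six-membered non-aromatic ring of carbon only), on an amide-type nitrogen. Within the data shown here, no pair of measured compounds isolates this change, so the direction of the step can only be judged loosely from the fact that compound 3, with its ring of carbon only on the amide nitrogen, stands highest at 990 nM. A step of a 3.3-fold lower number from compound 3 to compound 4 (0.52 log units; beyond the scatter) toward a lower number is expected. Compound 4 is expected to give about 300 nM in this assay, within a range from 60 nM to 1500 nM.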

Compound 4, half-maximal inhibitory concentration: 0.42 nM
Estimate against measurement, compound 4: 710-fold (2.85 log units) above, and the stated range ends above it.
By their numbers in this assay, from the lowest: compound 4; then compounds 1 and 2 (each within the scatter of the next); then compound 3.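

Among these compounds, replacing cyclohexyl on the amide-type nitrogen with the larger ring that holds one hetero atom gives a 2400-fold lower number from compound 3 to compound 4 (3.37 log units; beyond the scatter) in this assay, so a single change at this place can move the number very far, which no earlier pair could show. The change alters several things at once, adding a ring nitrogen, further carbons and a defined stereocentre, and the step belongs to the whole group rather than to any one of these. Nothing measured here bears on why the step is so large.

From the compounds shown here alone, it remains open how much of the step belongs to the ring nitrogen, the methyl groups or the stereocentre, which a tetrahydropyran ring or a plain piperidine ring on the same nitrogen could help to separate. Going by these compounds, the opposite arrangement at that stereocentre also remains open.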